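Series notes: methoxy to bromo on the pendant ring

The source may hold more compounds than are shown below. What is called first, only, known or untested is meant among the compounds shown, and "the series" means these compounds.

Compound 2 `COc1cccc(C2C(C#N)=C(N)Oc3cc(OC)ccc32)c1` sits second highest of the three numbers in a functional assay on T47D cells (Homo sapiens) for activation (a lower number here means that less compound is needed, a higher number that more compound is needed for the effect), where compound 2 gives 52000000 nM. Compound 1 `CCNc1ccc2c(c1)OC(N)=C(C#N)C2c1cccc(OC)c1` gives 110000000 nM, and compound 3 `COc1cc(OC)cc(C2C(C#N)=C(N)Oc3cc(OC)ccc32)c1` gives 15000000 nM. The measured steps are a 2.1-fold lower number from compound 1 to compound 2 (0.33 log units; beyond the scatter) and a 3.5-fold lower number from compound 2 to compound 3 (0.54 log units; beyond the scatter), both modest and both involving methoxy on an aromatic carbon. Compound 4 `COc1ccc2c(c1)OC(N)=C(C#N)C2c1cccc(Br)c1` differs from compound 2 by bromo in place of methoxy on an aromatic carbon. Among the compounds with values here, no measured step introduces bromo, so the direction rests on methoxy being lost; taking away a methoxy runs against the gain seen in a 3.5-fold lower number from compound 2 to compound 3 (0.54 log units; beyond the scatter), though on the other ring. Compound 4 is therefore expected to give a modest step, a 1.5-fold higher number from compound 2 to compound 4 (0.19 log units; within the scatter), with an estimated value of 80000000 nM in this assay, in the range 25000000 nM to 250000000 nM.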

Compound 4, half-maximal effective concentration: 52000000 nM
Compound 4: the middle estimate sits 1.5-fold (0.19 log units) above what was measured; measured number inside the range.
By their numbers in this assay, from the lowest: compound 3; then compounds 2 and 4 (each within the scatter of the next); then compound 1.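

In this assay, bromo in place of methoxy on this aromatic carbon gives (no change at the digits printed from compound 2 to compound 4 (within the scatter)). Within the data shown here, the position therefore tolerates the loss of the methoxy oxygen and its hydrogen-bond acceptor with no readable change, unlike the methoxy-related steps among the earlier compounds, which both lay beyond the scatter. No measured evidence bears on why methoxy and bromo read alike here.

Still open, on these data alone, is whether plain hydrogen, an amine, a carboxylic acid or a longer alkoxy chain on this carbon would also leave the number in place. Also open, as far as these compounds go, is whether bromo would behave the same alongside the second methoxy of compound 3.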